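Bromo in place of fluoro in a small series

The source may hold more compounds than are shown below. What is called first, only, known or untested is meant among the compounds shown, and "the series" means these compounds.

Measured so far in a functional assay on P388 cells (Mus musculus) for inhibition; a lower number here means a stronger inhibitor, a higher number a weaker inhibitor:
- Compound 1 `O=C1/C(=C/c2ccc(F)cc2)CCc2ccccc21`: 15900 nM
- Compound 2 `O=C1/C(=C/c2ccc(F)cc2)CCCc2ccccc21`: 11100 nM

Only these two compounds have been measured so far. Compound 2, at 11100 nM, lies within the usual scatter of compound 1, at 15900 nM, so the two numbers cannot be ranked against each other. Both stand in the same general range in this assay.

The next compound is compound 3 `O=C1/C(=C/c2ccc(Br)cc2)CCCc2ccccc21`, which has not yet been measured. Compared with compound 2, it carries bromo in place of fluoro on an aromatic carbon, para to a large group (bromo in place of fluoro on an aromatic carbon). Going by the values given here, no measured pair shows the outcome of this exchange, and the data offer no direct guide to its size. The expectation therefore starts from compound 2 at 11100 nM and stays close to that number. The expected change is a 1.2-fold lower number from compound 2 to compound 3 (0.09 log units; within the scatter), a slight shift toward a lower number that is not expected to go beyond the scatter. For compound 3 the estimated value is 9000 nM, with an expected range of 4000 nM to 20000 nM.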

Compound 3, half-maximal inhibitory concentration: 18600 nM
Compound 3: middle estimate off by 2.1-fold (0.32 log units), on the low side; measured number inside the range.
By their numbers in this assay, from the lowest: compounds 2, 1 and 3 (each within the scatter of the next).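

In this assay, going by these compounds alone, the exchange gives the first reading at this place, on an aromatic carbon para to a large group: bromo in place of fluoro produces a 1.7-fold higher number from compound 2 to compound 3 (0.22 log units; within the scatter), a step that lies within the scatter. On this single pair, the assay therefore does not separate bromo from fluoro, and compound 3 cannot be ranked against compound 2. The position accepts either group without a step beyond the scatter, although one pair cannot show whether that holds more widely, and nothing available bears on why the numbers fall where they do.

The compounds shown leave open whether a different group at this place, such as chloro, methoxy, a nitrile or an amine, would move the number beyond the scatter. They also leave open whether bromo in place of fluoro would read the same way on the core of compound 1, which so far carries only fluoro at this position.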